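This account rests on a few compounds, and the source may have more. Where it says the series, first, only, none or still open, it means among the compounds named here.

In a functional assay on KB cells (Homo sapiens) for cytotoxicity, read by sulforhodamine B assay (on this read-out higher numbers stand for an effect only at larger amounts of compound and lower numbers for an effect already at smaller amounts), compound 1 `COc1cccc(C2CC(=O)c3ccccc3N2)c1` gives 0.11 ug/mL. Compound 2 `COc1cccc(C2CC(=O)c3cc(N4CCCC4)ccc3N2)c1` gives 0.008 ug/mL, the lower of the two numbers. Within the data shown here, the only measured step, a 14-fold lower number from compound 1 to compound 2 (1.14 log units; beyond the scatter), put a pyrrolidin-1-yl in place of hydrogen on an aromatic carbon. Compound 3 `O=C1CC(c2cccc(Cl)c2)Nc2ccc(N3CCCC3)cc21` keeps that group and differs from compound 2 elsewhere: chloro in place of methoxy on an aromatic carbon, so chloro in place of methoxy on an aromatic carbon. The large measured step concerns another change, so it says little about this swap, and no shift beyond the scatter is expected. The estimated change is a 1.5-fold higher number from compound 2 to compound 3 (0.18 log units; within the scatter). Compound 3 is expected at 0.012 ug/mL, within an estimated range of 0.003 ug/mL to 0.05 ug/mL.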

Compound 3, concentration for half-maximal effect: 0.05 ug/mL
The estimate for compound 3 lay 4.2-fold (0.62 log units) below the measured number; the range from low to high includes it.
By their numbers in this assay, from the lowest: compound 2; then compound 3; then compound 1.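

With the pyrrolidin-1-yl kept, chloro in place of methoxy brings a 6.3-fold higher number from compound 2 to compound 3 (0.80 log units; beyond the scatter) in this assay. So the group on this ring also affects the number, and the methoxy of compound 2 is the better of the two groups here, although the step is modest. Nothing available here explains why these two groups differ.

Open, on these data alone, is how other groups at this place, such as fluoro, methyl, hydroxy or an amine, would compare. Also open, as far as these compounds go, is whether this swap would have the same effect without the pyrrolidin-1-yl.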